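The compounds below may be only part of what the source reports. "The series", "measured", "known", "first", "only" and "open" are said of these compounds alone.

Measured so far in a functional assay on LoVo cells (Homo sapiens) for inhibition, read by MTT assay, with a stated time of 48 h (on this read-out lower numbers stand for stronger inhibition and higher numbers for weaker inhibition), for three compounds:
- compound 1 `COc1ccc(N(C)c2nc(C)nc3ccccc23)cc1OCCCCCC[Se]C#N` gives 8580 nM
- compound 2 `Cc1nc(N(C)c2ccc([Se]C#N)c(C)c2)c2ccccc2n1` gives 19 nM
- compound 3 `COc1ccc(N(C)c2nc(C)nc3ccccc23)cc1C(=O)OCCC[Se]C#N` gives 854 nM

Compound 3, at 854 nM on this scale, sits in the middle of the three. Compound 4 `COc1ccc(N(C)c2nc(C)nc3ccccc23)cc1[Se]C` differs from compound 3 in one place (a group of 2 heavy atoms (1 carbon, 1 selenium; no ring) in place of a group of 9 heavy atoms (5 carbon, 1 nitrogen, 2 oxygen, 1 selenium; no ring), on an aromatic carbon), on an aromatic carbon ortho to a methoxy group. Among the measured compounds shown here, the one measured step at that carbon is a 10-fold lower number from compound 1 to compound 3 (1.00 log units; beyond the scatter) and there a large group gave way to one only slightly smaller. Compound 2 carries no long group and reads 19 nM but it differs from the others in more than one place, so it is only a loose guide. For the measured compounds named here, no measured pair tests so large a cut directly. Even so, a further drop in the number is expected, and the estimate is a 9.5-fold lower number from compound 3 to compound 4 (0.98 log units; beyond the scatter) in this assay with wide uncertainty. For compound 4 the estimated value is 90 nM within an expected range of 10 nM to 700 nM in this measurement.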

Compound 4, half-maximal inhibitory concentration: 3 nM
For compound 4 the middle estimate is 30-fold (1.48 log units) above the measured one; the measured number lies below the stated range.
By their numbers in this assay, from the lowest: compound 4; then compound 2; then compound 3; then compound 1.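

In this assay, the earlier step at this aromatic carbon only exchanged one long selenium-bearing group for another. The new steps, a 280-fold lower number from compound 3 to compound 4 (2.45 log units; beyond the scatter) and a 2900-fold lower number from compound 1 to compound 4 (3.46 log units; beyond the scatter), show that on this core the long group and its nitrile can be dispensed with entirely, and that a group of 2 heavy atoms (1 carbon, 1 selenium) at this carbon gives by far the lowest number of the series. Nothing available here explains why this small group reads so much lower.

On these data alone, what a methylthio group or a plain hydrogen would read at this carbon remains open, so the part played by the selenium itself is untested. Also open, as far as these compounds go, is whether a short selenium-bearing chain such as ethylseleno would hold the number this low.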